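Shortening an Ethyl to a Methyl on a Shared Core

The source may report more compounds than this note shows. Statements on the series, on what has been measured and on what is new or still open speak of the compounds shown alone.

Compound 1, `CC(=O)c1cccc(NC2=NCCC3(CCCCC3)S2)c1`: 74.7 10^-6 cm/s
Compound 2, `CCc1ccc(NC2=NCCC3(CCCCC3)S2)cc1`: 41 10^-6 cm/s
Compound 3, `CCc1cccc(CC)c1NC1=NCCC2(CCCCC2)S1`: 21.6 10^-6 cm/s

Of the compounds shown here, three built on one shared core have been measured in a physicochemical assay for permeability; a lower number here means that the compound crosses the layer more slowly, a higher number that the compound crosses the layer faster. Compound 1 gives 74.7 10^-6 cm/s, compound 2 gives 41 10^-6 cm/s, and compound 3 gives 21.6 10^-6 cm/s. Compound 2 is neither the top nor the bottom number of the three, yet its gap to compound 1 and its gap to compound 3 each fall within the usual scatter of repeated measurements, so on these numbers alone the three compounds cannot be told apart with confidence.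

Compound 4, `Cc1ccc(NC2=NCCC3(CCCCC3)S2)cc1`, has not yet been measured. It differs from compound 2 in one place: hydrogen in place of methyl on a saturated chain carbon bound to an aromatic carbon. Cut one bond further out, the same change reads ethyl to methyl; a single carbon leaves the chain and nothing else in the molecule is touched.

Going by the values given here, no pair of measured compounds differing in a single place is available here, so the size of such a step has not been seen directly. Since compound 1 at 74.7 10^-6 cm/s and compound 3 at 21.6 10^-6 cm/s both lie within the scatter around compound 2, and the change removes only one carbon, no step beyond the scatter is expected in this assay. Compound 4 is therefore estimated at 38 10^-6 cm/s, within a range from 22 10^-6 cm/s to 65 10^-6 cm/s. The step this estimate means, a 1.1-fold lower number from compound 2 to compound 4 (0.03 log units; within the scatter), is expected to stay within the scatter.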

Compound 4, apparent permeability: 5.67 10^-6 cm/s
Beside the measured number, compound 4's estimate is 6.7-fold (0.83 log units) above it; measured number outside the range, below it.
By their numbers in this assay, from the lowest: compound 4; then compounds 3, 2 and 1 (each within the scatter of the next, the first and the last beyond it).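

Removing a single carbon at this place is not a small change in this assay: going from ethyl to methyl gives a 7.2-fold lower number from compound 2 to compound 4 (0.86 log units; beyond the scatter). Going by these compounds alone, this is the first step seen between two measured compounds that differ in one place, and it shows that a change of just one carbon on the chain, with no ring, hydrogen-bond donor, hydrogen-bond acceptor or net charge leaving or entering, can carry the number beyond the scatter. Nothing measured here accounts for the size of this step.

Going by these compounds, a single pair gives one step and no trend, so it remains open whether a longer chain such as propyl, or an amine or a carboxylic acid carried on the same saturated chain carbon, would move the number further, bring it back, or leave it close to that of compound 2. On these data alone, it also remains open whether shortening an ethyl to a methyl would give a step of similar size elsewhere on the shared core.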